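The compounds below may be only part of what the source reports. "The series", "measured", "known", "first", "only" and "open" are said of these compounds alone.

Working notes on the series. Compound 1 `C=CCC(O/N=C(\C)C(=O)O)c1ccc(OCc2ccc3ccccc3n2)cc1` and compound 2 `C/C(=N\OC(Cc1ccccc1)c1ccc(OCc2ccc3ccccc3n2)cc1)C(=O)O` share one core; compound 2 differs in carrying a phenyl in place of the vinyl of compound 1. In a functional assay for inhibition of Polyunsaturated fatty acid 5-lipoxygenase (Homo sapiens) (a higher number here means a weaker inhibitor, a lower number a stronger inhibitor), compound 1 gives 142 nM and compound 2 gives 30 nM, a change of a 4.7-fold lower number from compound 1 to compound 2 (0.68 log units; beyond the scatter). Within the data shown here, compound 2 therefore stands at the lowest of the two numbers so far, with compound 1 as its only neighbour.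

Compound 3 `C/C(=N\OC(CCCc1ccc(F)cc1)c1ccc(OCc2ccc3ccccc3n2)cc1)C(=O)O` is not yet measured. It differs from compound 2 by 2-(4-fluorophenyl)ethyl in place of phenyl on a saturated chain carbon, two bonds along the chain from an aromatic carbon and an oxygen. Among the measured compounds shown here, the one step on record, from compound 1 to compound 2, concerns a different exchange at this position and cannot be carried over directly; it shows only that this carbon tolerates a larger group. The expected step in this assay from compound 2 to compound 3 is a 1.3-fold higher number from compound 2 to compound 3 (0.12 log units; within the scatter), with a wide range. Compound 3 is estimated at 40 nM, between 12 nM and 150 nM.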

Compound 3, half-maximal inhibitory concentration: 9 nM
The estimate for compound 3 lay 4.4-fold (0.65 log units) above the measured number; measured number outside the range, below it.
By their numbers in this assay, from the lowest: compound 3; then compound 2; then compound 1.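

In this assay the exchange of phenyl for 2-(4-fluorophenyl)ethyl on this saturated chain carbon lowers the number (a 3.3-fold lower number from compound 2 to compound 3 (0.52 log units; beyond the scatter)), so a group of 9 heavy atoms is accepted here in place of one of 6, and with a gain. Taken from the vinyl of compound 1, the whole change is large (a 16-fold lower number from compound 1 to compound 3 (1.20 log units; beyond the scatter)), and the three compounds fall in the order vinyl, phenyl, 2-(4-fluorophenyl)ethyl, with none going against that order. Nothing at hand accounts for these steps.

The exchange changes the chain and adds the fluorine together, so a 2-phenylethyl group would be needed to separate the two. Also open, from the compounds shown here alone, is how far the trend runs, for instance with a longer chain or with an amine on the end of the chain.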